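Bromine to Chlorine on the Chain-Bound Ring: One Estimate

This account rests on a few compounds, and the source may have more. Where it says the series, first, only, none or still open, it means among the compounds named here.

Measured compounds:
compound 1 `O=C(/C=C/c1ccc(Br)cc1)c1ccc(O)cc1O` — "not determined" (no result reported)
compound 2 `CCCc1c(O)ccc(C(=O)/C=C/c2ccc(Br)cc2)c1O` — "not determined" (no result reported)
compound 3 `CCCc1c(O)ccc(C(=O)/C=C/c2ccc(OC)cc2)c1O` — 24700 nM

Three compounds share one core, and all were run in a functional assay on NCI-H460 cells (Homo sapiens) for inhibition, read by sulforhodamine B assay, with a stated time of 48 h; on this read-out higher numbers stand for weaker inhibition of growth and lower numbers for stronger inhibition of growth. Only compound 3 comes out with a number, and in this assay compound 3 gives 24700 nM, which is weak inhibition of growth. Compound 2 stands without a number: its entry in this assay reads "not determined" (no result reported), and compound 1 is a second entry of the same kind. So there is no measured point for compound 2 to anchor a step from, and no step between two measured compounds exists in this set at all.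

Compound 4 `CCCc1c(O)ccc(C(=O)/C=C/c2ccccc2Cl)c1O` is the unmeasured one. It differs from compound 2 in one place: 2-chlorophenyl in place of 4-bromophenyl on a double-bonded chain carbon bound to a double-bonded chain carbon. With no step shown, the expectation for this change in this assay is a shift of no more than the usual scatter in either direction, so roughly the weak potency range that compound 3 shows. Compound 4 is therefore expected to give about 20000 nM, with a plausible range from 6000 nM to 70000 nM.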

Compound 4, concentration for 50% growth inhibition: 12500 nM
The estimate for compound 4 lay 1.6-fold (0.20 log units) above the measured number; measured number inside the range.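

In this assay compound 4 gives 12500 nM and compound 2 gives "not determined" (no result reported), so no new step can be read between them. The compounds shown leave open how exchanging 4-bromophenyl for 2-chlorophenyl changes inhibition of growth. No supporting data shown here bear on this result.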